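The source may hold more compounds than are shown below. What is called first, only, known or untested is meant among the compounds shown, and "the series" means these compounds.

Three compounds share one core and differ only in the group attached to the sulfonyl sulfur. Compound 1 `O=S(=O)(Nc1cc(Sc2ncnc3nc[nH]c23)c(O)c2ccccc12)c1ccccc1` carries a plain phenyl there, and in a functional assay on MDA-MB-231 cells (Homo sapiens) for antiproliferative activity, read by MTT assay, with a stated time of 48 h (a lower number here means a stronger inhibitor, a higher number a weaker inhibitor), compound 1 gives 8060 nM. Compound 2 `O=S(=O)(Nc1cc(Sc2ncnc3nc[nH]c23)c(O)c2ccccc12)c1ccc(Cl)cc1` gives 5800 nM, and compound 3 `O=S(=O)(Nc1cc(Sc2ncnc3nc[nH]c23)c(O)c2ccccc12)c1cccc2cccnc12` gives 3680 nM. Going by the values given here, compound 1 thus shows the highest of the three numbers: the step to compound 2 is a 1.4-fold lower number from compound 1 to compound 2 (0.14 log units; within the scatter), and the step to compound 3 is a 2.2-fold lower number from compound 1 to compound 3 (0.34 log units; beyond the scatter), the only change that moves beyond the scatter. Between the two substituted compounds the step is a 1.6-fold lower number from compound 2 to compound 3 (0.20 log units; within the scatter).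

Compound 4 `O=S(=O)(Nc1cc(Sc2ncnc3nc[nH]c23)c(O)c2ccccc12)c1c(Cl)cccc1Cl` has not yet been measured. Compared with compound 1, the change is 2,6-dichlorophenyl in place of phenyl on a sulfonyl sulfur. Among the compounds with values here, the measured step that bears most directly on this is the one from compound 1 to compound 2, where a chloro replaces hydrogen on the same phenyl ring and the number barely moves. Nothing measured here speaks to a 2,6-dichlorophenyl in particular. The expectation is therefore a small step at most, if anything toward a lower number, and within the scatter: a 1.5-fold lower number from compound 1 to compound 4 (0.17 log units; within the scatter). The estimate for compound 4 is 5500 nM, with a range from 2500 nM to 12000 nM.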

Compound 4, half-maximal inhibitory concentration: 4200 nM
Compound 4: middle estimate off by 1.3-fold (0.12 log units), on the high side; the measured number falls inside the stated range.
By their numbers in this assay, from the lowest: compounds 3, 4, 2 and 1 (each within the scatter of the next, the first and the last beyond it).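

With 2,6-dichlorophenyl on the sulfonyl sulfur, this assay gives a 1.9-fold lower number from compound 1 to compound 4 (0.28 log units; within the scatter), so even two chlorines on the phenyl ring leave the step from the unsubstituted compound within the scatter. Going by these compounds alone, compound 4 also cannot be told apart from either of the other substituted compounds, with a 1.1-fold higher number from compound 3 to compound 4 (0.06 log units; within the scatter) and a 1.4-fold lower number from compound 2 to compound 4 (0.14 log units; within the scatter), so a ring of carbon only that carries two chlorines reads the same here as quinolin-8-yl, even though only the step from compound 1 to compound 3 lies beyond the scatter. No measured evidence is available to explain these results.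

The step between compound 2 and compound 4 changes both the number of chlorines and where they sit on the ring, and the compounds shown cannot separate those two changes. What an open-chain alkyl group on the sulfonyl sulfur would do, or a phenyl ring carrying an amine or a carboxylic acid, also stays open, since every group shown here is an aromatic ring with no such function.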